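A few compounds are considered here, and "the series" means these few. Any claim that something is new, unique, unknown or untested is made for them only; others in the source may bear on it.

Measured so far in an ADME assay on Li23 cells (Homo sapiens) for cytotoxicity, read by WST assay; on this read-out lower numbers stand for higher toxicity in this test and higher numbers for lower toxicity in this test:
compound 1, `CN(c1ccc(C(O)(C(F)(F)F)C(F)(F)F)cc1)S(=O)(=O)c1ccccc1Br`, gives 9100 nM.
compound 2, `Cc1cccc(S(=O)(=O)N(C)c2ccc(C(O)(C(F)(F)F)C(F)(F)F)cc2)c1`, gives 11000 nM.
compound 3, `COc1cccc(S(=O)(=O)N(C)c2ccc(C(O)(C(F)(F)F)C(F)(F)F)cc2)c1`, gives 13000 nM.

Of the three numbers, that of compound 3 is the largest, but the steps leading to it, a 1.2-fold higher number from compound 2 to compound 3 (0.07 log units; within the scatter) and a 1.4-fold higher number from compound 1 to compound 3 (0.15 log units; within the scatter), are both within the scatter, as is a 1.2-fold higher number from compound 1 to compound 2 (0.08 log units; within the scatter). No order among the three is established in this assay; varying the aryl group on the sulfonyl sulfur has so far left the read-out flat.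

Compound 4, `COc1ccc(S(=O)(=O)N(C)c2ccc(C(O)(C(F)(F)F)C(F)(F)F)cc2)cc1`, is not yet measured. Its change from compound 3 is 4-methoxyphenyl in place of 3-methoxyphenyl on a sulfonyl sulfur. Within the data shown here, the measured steps that bear on it are the two that exchange the whole aryl group on the sulfonyl sulfur, a 1.2-fold higher number from compound 1 to compound 2 (0.08 log units; within the scatter) and a 1.4-fold higher number from compound 1 to compound 3 (0.15 log units; within the scatter), and the one that exchanges a substituent on that aryl group, a 1.2-fold higher number from compound 2 to compound 3 (0.07 log units; within the scatter); none of them moved the number beyond the scatter. Among the measured compounds shown here, a further variation of the same kind is therefore expected to stay in the same range, with no step in this assay beyond the scatter: the expected step is a 1.1-fold lower number from compound 3 to compound 4 (0.03 log units; within the scatter). Compound 4 is estimated at 12000 nM, with a range of 6000 nM to 24000 nM.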

Compound 4, half-maximal cytotoxic concentration: 7900 nM
Estimate against measurement, compound 4: 1.5-fold (0.18 log units) above, and the stated range covers the measured number.
By their numbers in this assay, from the lowest: compounds 4, 1, 2 and 3 (each within the scatter of the next).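

In this assay, exchanging 3-methoxyphenyl for 4-methoxyphenyl on the sulfonyl sulfur keeps the atoms the same and alters only how they are joined; this gives a 1.6-fold lower number from compound 3 to compound 4 (0.22 log units; within the scatter) and is the largest step in the set, yet it stays inside the scatter, so no order is established between the two methoxyphenyl compounds. The exchanges of whole aryl groups read the same way, with a 1.4-fold lower number from compound 2 to compound 4 (0.14 log units; within the scatter) for 4-methoxyphenyl in place of 3-methylphenyl and a 1.2-fold lower number from compound 1 to compound 4 (0.06 log units; within the scatter) for 4-methoxyphenyl in place of 2-bromophenyl, so all four compounds now stand within the scatter of one another and the read-out remains flat across this position. No measurement at hand explains where any of these numbers falls.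

The compounds shown leave open whether this flat read-out extends to an aryl group carrying an amine or a carboxylic acid, or to a longer chain in place of the aryl group on the sulfonyl sulfur. They also leave open whether replacing the methyl on the sulfonamide nitrogen with a longer chain would move the number beyond the scatter.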